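The compounds below may be only part of what the source reports. "The series", "measured", "known", "first", "only" and "open" are said of these compounds alone.

Measured so far in an assay for inhibition of S-methyl-5'-thioadenosine phosphorylase (Mus musculus); a lower number here means a stronger inhibitor, a higher number a weaker inhibitor:
- compound 1 `Nc1ncnc2c1ncn2C1O[C@H](CSCCCF)[C@@H](O)[C@H]1O`, 4000 nM
- compound 2 `Nc1ncnc2c1ncn2C1O[C@H](CSCCO)[C@@H](O)[C@H]1O`, 26000 nM

Compound 2 holds the highest of the two numbers; its nearest neighbour is compound 1, and the step of a 6.5-fold higher number from compound 1 to compound 2 (0.81 log units; beyond the scatter) lies beyond the scatter. Compound 3 `CCSC[C@H]1OC(n2cnc3c(N)ncnc32)[C@H](O)[C@@H]1O` differs from compound 2 by hydrogen in place of hydroxy on a saturated chain carbon, two bonds along the chain from a sulfur. Within the data shown here, the only step bearing on this change is the one from compound 1 to compound 2, where a hydroxy entering at the same place raised the number; taking the hydroxy away again is therefore expected to lower it in this assay. The step from compound 2 to compound 3 is estimated at a 4.3-fold lower number from compound 2 to compound 3 (0.64 log units; beyond the scatter). Compound 3 is expected to give 6000 nM, within 2000 nM to 18000 nM.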

Compound 3, inhibition constant: 1900 nM
The estimate for compound 3 lay 3.2-fold (0.50 log units) above the measured number, and the stated range ends above it.
By their numbers in this assay, from the lowest: compound 3; then compound 1; then compound 2.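

In this assay, hydroxy removal from this saturated chain carbon, 2-hydroxyethyl to ethyl, gives a 14-fold lower number from compound 2 to compound 3 (1.14 log units; beyond the scatter), so the hydroxy cost seen earlier against fluoromethyl is only part of its full cost against hydrogen. Fluoromethyl at the same carbon also sits on the higher side of hydrogen, with a 2.1-fold lower number from compound 1 to compound 3 (0.32 log units; beyond the scatter), leaving hydrogen with the lowest number of the three groups here. Nothing available accounts for either step. Still open, as far as these compounds go, is whether an amine or a carboxylic acid on this carbon, or a plain propyl chain, would fall below compound 3 in this assay.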